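Ethoxy for 5-nitrofuran-2-yl on the carbonyl carbon

A few compounds are considered here, and "the series" means these few. Any claim that something is new, unique, unknown or untested is made for them only; others in the source may bear on it.

Both compounds measured in a functional assay on NCI-H460 cells (Homo sapiens) for inhibition (a higher number here means a weaker inhibitor of growth, a lower number a stronger inhibitor of growth), as follows
- compound 1 `O=C(c1cc(Cl)nc(Cl)c1)N1CCc2cc(S(=O)(=O)N3C[C@H](c4ccccc4)NC3=O)ccc21` gives 700 nM
- compound 2 `O=C(c1ccc([N+](=O)[O-])o1)N1CCc2cc(S(=O)(=O)N3C[C@H](c4ccccc4)NC3=O)ccc21` gives 950 nM

For the measured compounds named here, compound 2 stands within the scatter of compound 1, the only other measured compound, with a 1.4-fold higher number from compound 1 to compound 2 (0.13 log units; within the scatter) as the single step. Compound 3 `CCOC(=O)N1CCc2cc(S(=O)(=O)N3C[C@H](c4ccccc4)NC3=O)ccc21` carries ethoxy in place of 5-nitrofuran-2-yl on a carbonyl carbon and has ethoxy in place of 5-nitrofuran-2-yl on a carbonyl carbon. Going by the values given here, the measured step exchanged one ring group for another, and no measured step removes the ring, so guidance is weak. In this assay no step beyond the scatter is expected, and the estimated step is a 1.3-fold higher number from compound 2 to compound 3 (0.10 log units; within the scatter) with no firm direction. Compound 3 is estimated at 1200 nM (range 400 nM to 3500 nM).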

Compound 3, concentration for 50% growth inhibition: 80 nM
Beside the measured number, compound 3's estimate is 15-fold (1.18 log units) above it; the whole stated range lies above it.
By their numbers in this assay, from the lowest: compound 3; then compounds 1 and 2 (each within the scatter of the next).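

In this assay the group on the carbonyl carbon can clearly shift growth inhibition: ethoxy in place of 5-nitrofuran-2-yl gives (a 12-fold lower number from compound 2 to compound 3 (1.07 log units; beyond the scatter)) and ethoxy in place of 2,6-dichloropyridin-4-yl gives (an 8.8-fold lower number from compound 1 to compound 3 (0.94 log units; beyond the scatter)). The exchange between the two ring groups stayed within the scatter, so a step beyond it appears here only with the ringless ethoxy. Nothing available accounts for these steps.

On these data alone, it remains open whether ethoxy itself matters or only the absence of an aromatic ring on the carbonyl carbon. Methoxy, a longer chain such as butoxy, or an amine such as dimethylamino at this place would help separate the two.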